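The compounds below may be only part of what the source reports. "The series", "measured", "known", "first", "only" and "open" are said of these compounds alone.

Among the compounds with values here, the three compounds measured so far share one core and differ only in the group attached to a carbonyl carbon. Compound 1 `CC(C)[C@@H](NC(=O)c1nc2ccccc2s1)C(=O)N1CCC(c2ccc(Cl)cc2)CC1` gives 18 nM in an assay on THP-1 cells for displacement of a labelled ligand from C-C chemokine receptor type 1 (Homo sapiens); on this read-out higher numbers stand for weaker inhibition and lower numbers for stronger inhibition. Compound 2 `CC(C)[C@@H](NC(=O)c1ccc(F)cc1)C(=O)N1CCC(c2ccc(Cl)cc2)CC1` gives 118 nM, and compound 3 `Cc1ccc(CCC(=O)N[C@@H](C(=O)N2CCC(c3ccc(Cl)cc3)CC2)C(C)C)cc1` gives 105 nM. Compound 3 therefore stands second highest of the three numbers: the step of a 1.1-fold lower number from compound 2 to compound 3 (0.05 log units; within the scatter) lies within the scatter, whereas a 5.8-fold higher number from compound 1 to compound 3 (0.77 log units; beyond the scatter) lies beyond it. The next compound, compound 4 `CC(C)[C@@H](NC(=O)Nc1ccccc1)C(=O)N1CCC(c2ccc(Cl)cc2)CC1`, differs from compound 3 by anilino in place of 2-(4-methylphenyl)ethyl on a carbonyl carbon. The earlier changes at this position, a 6.6-fold higher number from compound 1 to compound 2 (0.82 log units; beyond the scatter) and a 5.8-fold higher number from compound 1 to compound 3 (0.77 log units; beyond the scatter), show two quite different groups giving nearly the same number, with only compound 1 standing apart. The expected step is a 1.2-fold lower number from compound 3 to compound 4 (0.07 log units; within the scatter), not beyond the scatter. The estimate for compound 4 is 90 nM, within 30 nM to 300 nM.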

Compound 4, half-maximal inhibitory concentration: 616 nM
Compound 4: the middle estimate sits 6.8-fold (0.84 log units) below what was measured, outside the stated range (above it).
By their numbers in this assay, from the lowest: compound 1; then compounds 3 and 2 (each within the scatter of the next); then compound 4.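

Position tolerance turns out to be narrower than compound 2 and compound 3 suggested. Anilino gives a 5.9-fold higher number from compound 3 to compound 4 (0.77 log units; beyond the scatter) against 2-(4-methylphenyl)ethyl, a 5.2-fold higher number from compound 2 to compound 4 (0.72 log units; beyond the scatter) against 4-fluorophenyl and a 34-fold higher number from compound 1 to compound 4 (1.53 log units; beyond the scatter) against 1,3-benzothiazol-2-yl, so an aromatic ring of six carbons on this carbonyl carbon does not by itself keep the number low. Anilino also carries a hydrogen-bond donor that 2-(4-methylphenyl)ethyl lacks, but nothing available explains the rise.

On these data alone, whether the rise follows that nitrogen and its hydrogen remains open. A methyl(phenyl)amino or benzylamino group on the same carbonyl carbon would test this.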